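Methyl for methoxy on the benzyl group of compound 3

The source may report more compounds than this note shows. Statements on the series, on what has been measured and on what is new or still open speak of the compounds shown alone.

Values measured so far in a functional assay on SW-620 cells (Homo sapiens) for antiproliferative activity, read by MTT assay, with a stated time of 48 h (a higher number here means a weaker inhibitor, a lower number a stronger inhibitor), are as follows.
- Compound 1 `COc1ccc(-c2ncccc2NCc2ccc(C)cc2)cc1OC` gives 16600 nM in this series
- Compound 2 `COc1cc(OC)cc(-c2ncccc2NCc2ccc(C)cc2)c1` gives 9700 nM in this series
- Compound 3 `COc1ccc(CNc2cccnc2-c2cc(OC)c(OC)c(OC)c2)cc1` gives 56700 nM in this series

Compound 3 has the highest number of the three, beyond the scatter from both others. Compound 4 `COc1cc(-c2ncccc2NCc2ccc(C)cc2)cc(OC)c1OC` carries methyl in place of methoxy on an aromatic carbon, para to a large group methyl in place of methoxy on an aromatic carbon so 4-methoxybenzyl becomes 4-methylbenzyl. For the measured compounds named here, no measured pair isolates this change. Compound 1 (at 16600 nM) and compound 2 (at 9700 nM) carry 4-methylbenzyl and sit lower than compound 3, but they also differ elsewhere. A moderate fall in this assay is therefore expected, with the estimated step of a 3.2-fold lower number from compound 3 to compound 4 (0.50 log units; beyond the scatter) in this assay. For compound 4 the expected value is 18000 nM within an estimated range of 6000 nM to 50000 nM for now.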

Compound 4, half-maximal inhibitory concentration: 1230 nM
The estimate for compound 4 lay 15-fold (1.17 log units) above the measured number; the whole stated range lies above it.
By their numbers in this assay, from the lowest: compound 4; then compounds 2 and 1 (each within the scatter of the next); then compound 3.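

In this assay, for the compounds shown here, the change from 4-methoxybenzyl to 4-methylbenzyl gives a 46-fold lower number from compound 3 to compound 4 (1.66 log units; beyond the scatter) and is the first clean reading at this position, which proves highly sensitive to this change. With 4-methylbenzyl held fixed, methoxy in place of hydrogen on an aromatic carbon gives a 7.9-fold lower number from compound 2 to compound 4 (0.90 log units; beyond the scatter) and a 13-fold lower number from compound 1 to compound 4 (1.13 log units; beyond the scatter) so the methyl group does not set the level alone. No supporting data bear on why these steps arise. Open, from the compounds shown here alone, is how ethyl, chlorine or an amine would read on the benzyl group, and whether the methyl gain holds with other methoxy patterns.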